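Shortening the hydroxamate linker on the shared core

The source may hold more compounds than are shown below. What is called first, only, known or untested is meant among the compounds shown, and "the series" means these compounds.

Among the compounds with values here, compound 2 `Nc1ncnc2c1c(-c1cnc3[nH]ccc3c1)nn2CCCCCCCCCC(=O)NO` gives 11700 nM in a functional assay on HepG2 cells (Homo sapiens) for inhibition, read by MTT assay, with a stated time of 72 h (on this read-out lower numbers stand for stronger inhibition and higher numbers for weaker inhibition), the highest of the two numbers so far; compound 1 `Nc1ncnc2c1c(-c1cnc3[nH]ccc3c1)nn2CCCCCCCCC(=O)NO` gives 3050 nM. Within the data shown here, the one measured step, a 3.8-fold higher number from compound 1 to compound 2 (0.58 log units; beyond the scatter), shows a longer chain raising the number. Compound 3 `Nc1ncnc2c1c(-c1cnc3[nH]ccc3c1)nn2CCCC(=O)NO` carries the change (hydroxycarbamoyl in place of 6-(hydroxycarbamoyl)hexyl on a saturated chain carbon, three bonds along the chain from an aromatic nitrogen). The shortening runs opposite to that step and would by itself point to a lower number, but it is far larger than any change measured, so a wide range is expected. For compound 3 the estimate is 4500 nM (range 700 nM to 30000 nM), a step of a 2.6-fold lower number from compound 2 to compound 3 (0.41 log units; beyond the scatter).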

Compound 3, half-maximal inhibitory concentration: > 50000 nM
Compound 3: a limit, no number; the forecaster's own chance of this, stated with the estimate: 10%; middle value at least 11-fold (1.04 log units) away from the limit.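

Compound 3 sits at a limit of the assay, not at a number: the limit of > 50000 nM in this assay, at which 1 of the 3 values shown sits. The shortening therefore does not continue the direction of the earlier step and instead gives an at least 4.2-fold higher number from compound 2 to compound 3 (0.63 log units; beyond the scatter), while the comparison with the other chain gives an at least 16-fold higher number from compound 1 to compound 3 (1.21 log units; beyond the scatter). The number thus does not follow chain length in one direction: compound 3 goes against the earlier trend, and compound 1 has the lowest number of the three in this assay.

Still open, as far as these compounds go, is where, between the chains of compound 3 and compound 1, the number begins to climb. Also open, from the compounds shown here alone, is how a carboxylic acid in place of the hydroxycarbamoyl end would read on the chain of compound 1.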